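The compounds below may be only part of what the source reports. "The series", "measured", "known", "first", "only" and "open" are said of these compounds alone.

Compound 1 `COc1cc2c(Nc3ccc(C#N)cc3)ncnc2cc1OCCCN1CCCCC1`: 23500 nM
Compound 2 `COc1cc2c(Nc3ccc(C#N)cc3)ncnc2cc1OCCCN1CCC(N2CCCCC2)CC1`: 30700 nM
Compound 3 `CCN1CCN(CCCOc2cc3ncnc(Nc4ccc(C#N)cc4)c3cc2OC)CC1`: 16000 nM

In a functional assay on A549 cells (Homo sapiens) for antiproliferative activity, read by MTT assay, with a stated time of 72 h (a lower number here means a stronger inhibitor, a higher number a weaker inhibitor), compound 1 stands level with the other two compounds: a 1.3-fold higher number from compound 1 to compound 2 (0.12 log units; within the scatter), and a 1.5-fold lower number from compound 1 to compound 3 (0.17 log units; within the scatter).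

Compound 4 `COc1cc2c(Nc3cccc(C#N)c3)ncnc2cc1OCCCN1CCCCC1` has 3-cyanophenyl in place of 4-cyanophenyl on a nitrogen on an aromatic ring. Among the measured compounds shown here, no measured step touches this group. All of them alter the piperidin-1-yl end instead, and even a 1.9-fold lower number from compound 2 to compound 3 (0.28 log units; within the scatter) stays small. The data therefore give no direct guide to this change, and no step beyond the scatter is expected.

The estimate means an expected 1.1-fold lower number from compound 1 to compound 4 (0.03 log units; within the scatter).

Compound 4 is expected at about 22000 nM, with an estimated range of 9000 nM to 50000 nM.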

Compound 4, half-maximal inhibitory concentration: 37000 nM
Compound 4: the middle estimate sits 1.7-fold (0.23 log units) below what was measured, within the range that was stated.
By their numbers in this assay, from the lowest: compounds 3, 1, 2 and 4 (each within the scatter of the next, the first and the last beyond it).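

Putting 3-cyanophenyl in place of 4-cyanophenyl on the nitrogen gives a 1.6-fold higher number from compound 1 to compound 4 (0.20 log units; within the scatter) in this assay. Among the compounds shown here, this is the first measured change at this group, and this assay does not tell the two cyanophenyl groups apart, just as it did not separate the changes at the piperidin-1-yl end. No supporting measurement bears on this result.

The compounds shown leave open whether a group other than nitrile on the phenyl ring, such as a chlorine or a carboxylic acid, would give a step beyond the scatter. They also leave open how 3-cyanophenyl behaves alongside the 4-ethylpiperazin-1-yl end of compound 3.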